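This account rests on a few compounds, and the source may have more. Where it says the series, first, only, none or still open, it means among the compounds named here.

Compound 2 `Cc1cccc(Nc2ncnc3c2nnn3Cc2ccccc2)c1` is the weaker of the two compounds with numbers in an assay on cell membranes for binding affinity to adenosine receptor A1 (Bos taurus), read by radioligand binding; on this read-out higher numbers stand for weaker inhibition and lower numbers for stronger inhibition: compound 2 gives 1100 nM, while compound 1 `Clc1ccccc1Cn1nnc2c(NC3CCCC3)ncnc21` gives 21 nM, a gap that lies well beyond the usual scatter. Compound 1 differs from compound 2 in more than one place, so no single change can be read from that pair. Compound 3 `Cc1cccc(Nc2ncnc3c2nnn3Cc2ccccc2Cl)c1` is compound 2 with one alteration: chloro in place of hydrogen on an aromatic carbon, on an aromatic carbon of a six-membered aromatic ring of carbon only, ortho to a large group; read one bond further out, benzyl becomes 2-chlorobenzyl. Going by the values given here, no measured pair isolates this change, and the only compound that carries the 2-chlorobenzyl group, compound 1, also carries a different amine. The step from compound 2 to compound 3 in this assay is therefore estimated as a moderate improvement, a 2.4-fold lower number from compound 2 to compound 3 (0.39 log units; beyond the scatter), with little confidence in either direction. For compound 3 the expected value in this assay is 450 nM, within a range from 150 nM to 1500 nM.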

Compound 3, inhibition constant: 5880 nM
Compound 3: middle estimate off by 13-fold (1.12 log units), on the low side, outside the stated range (above it).
By their numbers in this assay, from the lowest: compound 1; then compound 2; then compound 3.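

In this assay, chloro on an aromatic carbon, ortho to a large group, turning benzyl into 2-chlorobenzyl, is no gain on the 3-methylphenyl amine: the change gives a 5.3-fold higher number from compound 2 to compound 3 (0.73 log units; beyond the scatter) and so weakens inhibition in this pair. With compound 3 now sharing the 2-chlorobenzyl group with compound 1, the amine substituent can be read on its own, and 3-methylphenyl in place of cyclopentyl on a nitrogen on an aromatic ring gives a 280-fold higher number from compound 1 to compound 3 (2.45 log units; beyond the scatter) as a large loss, against the modest loss from the chloro change. Nothing at hand explains either step.

The compounds shown leave open how chloro at this position behaves on the cyclopentyl amine, so these two steps cannot be said to add up or to depend on each other. They also leave open whether fluoro or methoxy on the same aromatic carbon, or cyclohexyl or a longer alkyl chain on the amine nitrogen, would follow the same direction.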